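Benzyl to methyl on an aryl ether: expected lipophilicity

The source may report more compounds than this note shows. Statements on the series, on what has been measured and on what is new or still open speak of the compounds shown alone.

Of the compounds shown here, three have been measured in a physicochemical assay for lipophilicity; a higher number here means a more lipophilic compound, a lower number a more polar compound. Compound 1 `CSC1CN(c2ccccc2)NC1=O` gives 1.97. Compound 2 `O=C1NN(c2ccccc2)CC1SCc1ccccc1` gives 3.63. Compound 3 `COCCC1CN(c2ccc(OCc3ccccc3)cc2)NC1=O` gives 2.22; how the core of compound 3 differs from the core of compound 2 is not broken down here. The gap between compound 3 and compound 1 lies within the scatter, while the gap between compound 3 and compound 2 lies beyond it.

One structural change occurs twice among these compounds. From compound 2 to compound 1 it reads (hydrogen in place of phenyl on a saturated chain carbon bound to a sulfur), and the step in this assay is a number 1.66 log units lower from compound 2 to compound 1 (beyond the scatter). Compound 4 `COCCC1CN(c2ccc(OC)cc2)NC1=O` has not yet been measured; set against compound 3 it reads (hydrogen in place of phenyl on a saturated chain carbon bound to an oxygen on an aromatic ring). The two places are not the same word for word: in the measured pair the saturated chain carbon is bound to a sulfur, in the new pair it is bound to an oxygen on an aromatic ring. The change is therefore of the same kind, not the same. Going by the values given here, the expectation for compound 4 rests on the single measured step of this kind, a number 1.66 log units lower from compound 2 to compound 1 (beyond the scatter), and nothing else in the set speaks for or against transferring it.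

The step from compound 3 to compound 4 in this assay is expected to be a number 1.57 log units lower from compound 3 to compound 4 (beyond the scatter), close in size to the measured one. Compound 4 is accordingly expected to give 0.65, with a plausible range from 0.1 to 1.2.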

Compound 4, partition coefficient: 0.45
Beside the measured number, compound 4's estimate is 0.20 log units above it, within the range that was stated.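

In this assay the new step reads a number 1.77 log units lower from compound 3 to compound 4 (beyond the scatter) and runs the same way as the earlier one, a number 1.66 log units lower from compound 2 to compound 1 (beyond the scatter), so in both pairs shown the change of benzyl to methyl, hydrogen in place of phenyl, goes with a large fall in the number. This shows that the change carried from the core of compound 2 to the core of compound 3 with the same direction and the same printed size class, even though the place differs, on a saturated chain carbon bound to a sulfur in one pair and on a saturated chain carbon bound to an oxygen on an aromatic ring in the other; it does not show a rule for the series, as it rests on only these two pairs and says nothing about any further core. Nothing at hand bears on why the two steps agree.

The compounds shown leave open whether the step would hold on a core that also carries an amine or a carboxylic acid. They also leave open what a longer chain such as phenethyl would give in place of benzyl, and whether the number would keep falling along the series from phenethyl through benzyl to methyl.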